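Methyl in place of ring hydrogen: expectation for compound 4

The compounds below may be only part of what the source reports. "The series", "measured", "known", "first", "only" and "open" are said of these compounds alone.

Measured compounds:
- Compound 1, `Cc1ccnc(/C(N)=N/NC(=S)N2CCSCC2)c1`: 39.2%
- Compound 2, `N/C(=N\NC(=S)N1CCOCC1)c1ccc(F)cn1`: 81.9%
- Compound 3, `N/C(=N\NC(=S)N1CCOCC1)c1ccccn1`: 56.3%

In a functional assay on HeLa cells (Homo sapiens) for cytotoxicity, read by MTT assay, with a stated time of 72 h, tested at 10 uM (on this read-out lower numbers stand for less inhibition of growth and higher numbers for more inhibition of growth at the one concentration tested), compound 3 stands second highest of the three numbers. Its nearest neighbour is compound 1, which gives 39.2%, a value beyond the scatter below it; the furthest is compound 2, which gives 81.9%, beyond the scatter above it. Among the compounds with values here, the one measured step, a number 25.6 percentage points lower from compound 2 to compound 3 (beyond the scatter), shows that a change on an aromatic carbon of the shared core can shift the read-out by a modest amount.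

Compound 4, `Cc1ccnc(/C(N)=N/NC(=S)N2CCOCC2)c1`, differs from compound 3 by methyl in place of hydrogen on an aromatic carbon. Within the data shown here, no measured step shows this exact change with the same ring partner. Among the measured compounds shown here, compound 1 does carry a methyl on its ring but with a different saturated ring elsewhere, and its value sits below that of compound 3; no step is computed between them, so only their two values can be compared. Drawing on the size of the measured step, a modest downward step is expected for compound 4, giving a number 10.3 percentage points lower from compound 3 to compound 4 (beyond the scatter). The estimate for compound 4 in this assay is 46%, within 30% to 62%.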

Compound 4, percent growth inhibition at one concentration: 49.1%
Estimate against measurement, compound 4: 3.1 percentage points below; the range from low to high includes it.
By their numbers in this assay, from the lowest: compounds 1, 4 and 3 (each within the scatter of the next, the first and the last beyond it); then compound 2.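

In this assay, methyl in place of hydrogen on the aromatic carbon opposite the ring nitrogen gives a number 7.2 percentage points lower from compound 3 to compound 4 (within the scatter) and so, unlike the fluoro change in the earlier step, leaves the two compounds inseparable on this read-out. Within the data shown here, the new compound also provides the first single-place comparison of the saturated ring, with a number 9.9 percentage points higher from compound 1 to compound 4 (within the scatter) for morpholin-4-yl in place of thiomorpholin-4-yl on a thiocarbonyl carbon, so this pair is not separated either. Nothing measured here gives a reason for either step.

The compounds shown leave open whether a longer chain such as ethyl, or an amine, on this same aromatic carbon would stay within the scatter of compound 3. They also leave open whether a methoxy group there would do so.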